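Replacing the urea of compound 3 with a hexylamine

This account rests on a few compounds, and the source may have more. Where it says the series, first, only, none or still open, it means among the compounds named here.

Of the compounds shown here, three built on one shared core have so far been tested in an assay on aorta for inhibition of acyl-CoA:cholesterol acyltransferase (Oryctolagus cuniculus); a higher number here means a weaker inhibitor, a lower number a stronger inhibitor. Compound 1 `CCCCNC(=O)Nc1c(OCCCn2cnc(-c3ccccc3)c2)cccc1N(C)C` gives 810 nM. Compound 3 `CN(C)c1cccc(OCCCn2cnc(-c3ccccc3)c2)c1NC(=O)NC1CCCCC1` gives 1070 nM, a value that lies within the usual scatter of the result for compound 1, so the two cannot be told apart. Compound 2 `CCNC(=O)Nc1c(OCCCn2cnc(-c3ccccc3)c2)cccc1N(C)C` reaches only a limit of this assay, > 10000 nM. Among the measured steps, a 1.3-fold higher number from compound 1 to compound 3 (0.12 log units; within the scatter) is small, whereas an at least 12-fold higher number from compound 1 to compound 2 (1.09 log units; beyond the scatter) and an at least 9.3-fold lower number from compound 2 to compound 3 (0.97 log units; beyond the scatter) are large; the one limit involved is the limit of > 10000 nM in this assay, at which 1 of the 3 values shown sits.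

Compound 4 `CCCCCCNc1c(OCCCn2cnc(-c3ccccc3)c2)cccc1N(C)C` differs from compound 3 by hexyl in place of cyclohexylcarbamoyl on a nitrogen on an aromatic ring. Among the measured compounds shown here, none of the measured steps removes the urea; each of them only alters the group on its far nitrogen, and there the short ethyl of compound 2 gave the weakest result. The change to compound 4 is larger than any step measured so far, so its outcome is uncertain, but a move towards a weaker inhibitor is expected. Compound 4 is therefore estimated at 5000 nM, within a range from 1000 nM to 30000 nM, which means an expected 4.7-fold higher number from compound 3 to compound 4 (0.67 log units; beyond the scatter).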

Compound 4, half-maximal inhibitory concentration: 3300 nM
The estimate for compound 4 lay 1.5-fold (0.18 log units) above the measured number; low and high end bracket the measured number.
By their numbers in this assay, from the lowest: compounds 1 and 3 (each within the scatter of the next); then compound 4. At a limit, above all of these: compound 2.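

In this assay, among the compounds shown here, this is the first change that removes the urea itself rather than altering the group on its far nitrogen, and activity falls but survives, with a 3.1-fold higher number from compound 3 to compound 4 (0.49 log units; beyond the scatter) and a 4.1-fold higher number from compound 1 to compound 4 (0.61 log units; beyond the scatter). The urea therefore contributes at this nitrogen on the aromatic ring but is not essential, even though hexyl brings no hydrogen-bond donor or acceptor, whereas the cyclohexylcarbamoyl group it replaces has one of each. A long hexyl without the urea also does better than the short ethyl urea, with an at least 3.0-fold lower number from compound 2 to compound 4 (0.48 log units; beyond the scatter), and this step has only a bound on its size, as the result for compound 2 is a limit rather than a number: the limit of > 10000 nM in this assay, at which 1 of the 4 values shown sits.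

The compounds shown cannot say whether the loss comes from the carbonyl, from the far urea nitrogen or from the change in the chain itself, and a hexanoyl amide, which keeps the carbonyl without that nitrogen, would help to separate these. Going by these compounds, how chain length matters on a simple amine at this position also remains open, and a butyl or octyl chain there would test it.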